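This account rests on a few compounds, and the source may have more. Where it says the series, first, only, none or still open, it means among the compounds named here.

Three compounds built on one shared core were examined in an ADME assay on Vero cells (Chlorocebus sabaeus) for cytotoxicity, read by MTT assay, with a stated time of 72 h; on this read-out lower numbers stand for higher toxicity in this test and higher numbers for lower toxicity in this test. Compound 1 `COC(=O)c1cc(-c2cccc(NC(=O)c3ccc(/C=C/C(=O)c4cc(F)ccc4F)cc3)c2)on1` carries a 2,5-difluorophenyl group on a carbonyl carbon. In this assay compound 1 reaches only a limit of the test, > 40 ug/mL. Compound 2 `COC(=O)c1cc(-c2cccc(NC(=O)c3ccc(/C=C/C(=O)c4ccc(F)cc4F)cc3)c2)on1` carries a 2,4-difluorophenyl group at that carbonyl carbon. In this assay compound 2 likewise reaches only a limit, > 40 ug/mL. Compound 3 `COC(=O)c1cc(-c2cccc(NC(=O)c3ccc(/C=C/C(=O)c4ccccc4C)cc3)c2)on1` carries a 2-methylphenyl group there. In this assay compound 3 gives no number but a limit, > 25 ug/mL. With every value sitting at a limit, the limit of > 40 ug/mL in this assay, at which 2 of the 3 values shown sit, and (the limit of > 25 ug/mL in this assay, at which 1 of the 3 values shown sits), the steps a step that the two limits leave unreadable from compound 1 to compound 2, a step that the two limits leave unreadable from compound 1 to compound 3 and a step that the two limits leave unreadable from compound 2 to compound 3 cannot be sized, so compound 3 stands no higher or lower than its neighbours on what is known.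

Compound 4 `COC(=O)c1cc(-c2cccc(NC(=O)c3ccc(/C=C/C(=O)c4ccc(C)c([N+](=O)[O-])c4)cc3)c2)on1` differs from compound 3 by 4-methyl-3-nitrophenyl in place of 2-methylphenyl on a carbonyl carbon. Within the data shown here, no measured step speaks to a change of this kind, and the three limits give no direction. The expected step that the limit leaves unreadable from compound 3 to compound 4 is therefore none beyond the scatter. Compound 4 is estimated at 40 ug/mL, with a range from 25 ug/mL to 80 ug/mL.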

Compound 4, half-maximal cytotoxic concentration: > 80 ug/mL
Compound 4: no number, only a limit; the forecaster's own chance of this, stated with the estimate: 75%; at least 2.0-fold (0.30 log units) between middle value and limit.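

In this assay compound 4 gives only a limit, > 80 ug/mL. Its steps from compound 1, compound 2 and compound 3 cannot be read. The compounds shown leave open what concentration harms these cells, and whether changing the aryl group on the carbonyl carbon alters it at all.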